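A few compounds are considered here, and "the series" means these few. Any claim that something is new, unique, unknown or untested is made for them only; others in the source may bear on it.

Compound 1 `O=C(CCCCC1CCSS1)NCc1cn(CCCOc2ccc3cc(-c4ccccc4)c(=O)oc3c2)nn1` and compound 2 `CCOC(=O)c1cc2ccc(OCCCCCn3cc(CNC(=O)CCCCC4CCSS4)nn3)cc2oc1=O` share a common core. In a functional assay on PC-12 cells (Rattus norvegicus) for cytotoxicity, read by MTT assay, with stated times of 3 h and 2 h, tested at 5 uM (a lower number here means a weaker effect, a higher number a stronger effect of the compound at the concentration tested), compound 1 gives 29.8%, and compound 2 gives 36.4%, the higher of the two numbers recorded, though its gap to compound 1 lies within the scatter of repeated measurements. Compound 3 `COc1ccc(-c2cc3ccc(OCCCCCn4cc(CNC(=O)CCCCC5CCSS5)nn4)cc3oc2=O)cc1OC` differs from compound 2 in one place: 3,4-dimethoxyphenyl in place of ethoxycarbonyl on an aromatic carbon. Within the data shown here, no measured pair shows what such a change does, so any shift in this assay remains open. Compound 3 is expected to give 36%, within 24% to 48%, a step of a number 0.4 percentage points lower from compound 2 to compound 3 (within the scatter) expected to stay within the scatter.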

Compound 3, a percentage reported as activity, at one concentration (the size of the read-out at that concentration, not a potency): 46.9%
The estimate for compound 3 lay 10.9 percentage points below the measured number; the measured number falls inside the stated range.
By their numbers in this assay, from the lowest: compounds 1 and 2 (each within the scatter of the next); then compound 3.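

At the aromatic carbon two atoms from the ring oxygen, 3,4-dimethoxyphenyl in place of ethoxycarbonyl gives a number 10.5 percentage points higher from compound 2 to compound 3 (beyond the scatter) in this assay. This shows that the group at this position can change the read-out, even though the two groups have the same count of hydrogen-bond acceptors. Nothing available explains the shift. Going by these compounds, whether the increase needs both methoxy groups or the added aromatic ring remains open. So does the outcome with an amine or a carboxylic acid on this carbon.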